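The source may report more compounds than this note shows. Statements on the series, on what has been measured and on what is new or still open speak of the compounds shown alone.

Within the data shown here, compound 1 `COc1cccc(/C(=C\c2cn(C(C)=O)c3ccc(OCc4ccccc4)cc23)C(=O)O)c1` is one of two compounds with a number so far in a functional assay on DU-145 cells (Homo sapiens) for cytotoxicity, read by MTT assay, with a stated time of 72 h (a higher number here means a weaker inhibitor, a lower number a stronger inhibitor), and in this assay compound 1 gives 1080 nM, the lowest of the two. Among the measured compounds shown here, compound 2 `COc1ccc(/C(=C\c2c[nH]c3ccc(OCc4ccccc4)cc23)C(=O)O)cc1` is the only other measured compound; in this assay compound 2 gives 38100 nM, a much weaker result, but compound 2 differs from compound 1 in more than one place, so the two numbers cannot be tied to any single change.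

Compound 3 `COc1ccc(OC)c(/C(=C\c2cn(C(C)=O)c3ccc(OCc4ccccc4)cc23)C(=O)O)c1` keeps the core of compound 1 and differs from it in one spot: methoxy in place of hydrogen on an aromatic carbon. Put another way, the 3-methoxyphenyl of compound 1 becomes a 2,5-dimethoxyphenyl, with the new methoxy sitting ortho to the large group and para to the methoxy already present. For the measured compounds named here, no measured pair shows what a second methoxy at this place does, so the direction of the step is open; a small shift in either direction, within or just beyond the scatter, seems the most likely outcome. On that basis compound 3 is expected to give about 1500 nM, somewhere between 500 nM and 5000 nM, which would mean an expected step of a 1.4-fold higher number from compound 1 to compound 3 (0.14 log units; within the scatter).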

Compound 3, half-maximal inhibitory concentration: 830 nM
For compound 3 the middle estimate is 1.8-fold (0.26 log units) above the measured one; measured number inside the range.
By their numbers in this assay, from the lowest: compounds 3 and 1 (each within the scatter of the next); then compound 2.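

Among these compounds, the step from hydrogen to methoxy is the first change in this set that can be read at a single place, and in this assay it comes to a 1.3-fold lower number from compound 1 to compound 3 (0.11 log units; within the scatter). A second methoxy, ortho to a large group and para to a methoxy group, therefore gives a number that cannot be told apart from that of the parent, so the 3-methoxyphenyl and the 2,5-dimethoxyphenyl read alike here, at least for this one group at this one carbon. Nothing measured on these compounds speaks to why the two numbers lie so close.

Going by these compounds, whether this aromatic carbon would read the same with a different group remains open, since a hydroxyl, an amine, a fluorine atom or a longer chain such as ethoxy could give a number well apart from these two or one just as close. The much higher number of compound 2 also stays unexplained, as compound 2 differs from both compound 1 and compound 3 in more than one place, and no single change links it to either of them.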